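This account rests on a few compounds, and the source may have more. Where it says the series, first, only, none or still open, it means among the compounds named here.

Of the compounds shown here, two built on the same core have been measured so far in a physicochemical assay for lipophilicity, using the shake flask method, measured as octanol-water partition, at pH 7.4 (a higher number here means a more lipophilic compound, a lower number a more polar compound), and they differ at one place only. Compound 1 `CNC(=O)CN1CCC(c2cc3c(-c4ccc(=O)n(C(C)C)c4)ccnc3[nH]2)CC1` gives 2.2 on this scale, while compound 2 `CC(C)n1cc(-c2ccnc3[nH]c(C4CCN(Cc5cccs5)CC4)cc23)ccc1=O` gives 3.4 as the higher of the two numbers. Compound 3 `CC(C)n1cc(-c2ccnc3[nH]c(C4CCN(CC(=O)N5CCCCC5)CC4)cc23)ccc1=O` keeps the core of compound 2 but puts (piperidin-1-yl)carbonyl in place of thiophen-2-yl on a saturated chain carbon bound to an amine nitrogen in a ring, and the counted difference is (piperidin-1-yl)carbonyl in place of thiophen-2-yl on a saturated chain carbon bound to an amine nitrogen in a ring in full.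

Among the compounds with values here, one measured step bears on this change. Thiophen-2-yl in place of methylcarbamoyl at that same place gave a number 1.20 log units higher from compound 1 to compound 2 (beyond the scatter) as a large step. The group entering compound 3 resembles methylcarbamoyl in holding a carbonyl, so a move back down is expected, but it also brings a six-membered non-aromatic ring, so only part of that distance seems likely. The estimate is a number 0.40 log units lower from compound 2 to compound 3 (beyond the scatter) as a moderate fall. Compound 3 is therefore expected at 3 in this assay with an estimated range of 2.6 to 3.4 for this measurement.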

Compound 3, distribution coefficient: 2.8
For compound 3 the middle estimate is 0.20 log units above the measured one; the range from low to high includes it.
By their numbers in this assay, from the lowest: compound 1; then compound 3; then compound 2.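

In this assay, (piperidin-1-yl)carbonyl in place of thiophen-2-yl on a saturated chain carbon bound to an amine nitrogen in a ring gives a number 0.60 log units lower from compound 2 to compound 3 (beyond the scatter) and so brings the number down, which shows that the position can also move downward from the thiophen-2-yl compound. Compound 1 and compound 3 both hold a carbonyl at this place, yet they are not equal: piperidin-1-yl in place of methylamino on the carbonyl carbon gives a number 0.60 log units higher from compound 1 to compound 3 (beyond the scatter) and places compound 3 between the other two compounds, so what is attached to the carbonyl also matters here, not only the carbonyl itself. Nothing available here accounts for the size of either step.

Going by these compounds, it remains open whether the rise from methylamino to piperidin-1-yl follows the ring itself or only the added carbons, and an open-chain diethylamino group on the same carbonyl carbon would help separate the two. Also open, on these data alone, is where a phenyl ring, a morpholin-4-yl group on the carbonyl carbon or a carboxylic acid at this place would fall on the same scale.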